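The source may report more compounds than this note shows. Statements on the series, on what has been measured and on what is new or still open speak of the compounds shown alone.

Compound 1 `COC(=O)C1=CO[C@@H](O[C@@H]2O[C@H](COC(c3ccccc3)(c3ccccc3)c3ccccc3)[C@@H](OC(=O)O)[C@H](OC(C)=O)[C@H]2OC(C)=O)[C@@H]2[C@@H](C)[C@@H](OC(C)=O)C[C@H]12`: 1.2 ug/mL
Compound 2 `CCC(=O)OC[C@H]1O[C@@H](O[C@@H]2OC=C(C(=O)OC)[C@H]3C[C@H](OC(C)=O)[C@H](C)[C@@H]23)[C@H](OC(C)=O)[C@@H](OC(C)=O)[C@@H]1OC(C)=O`: 4.26 ug/mL
Compound 3 `CCCCCCCCCCCC(=O)OC[C@H]1O[C@@H](O[C@@H]2OC=C(C(=O)OC)[C@H]3C[C@H](OC(C)=O)[C@H](C)[C@@H]23)[C@H](OC(C)=O)[C@@H](OC(C)=O)[C@@H]1OC(C)=O`: 0.75 ug/mL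

In a functional assay on MCF7 cells (Homo sapiens) for cytotoxicity, read by colony formation (a higher number here means a weaker inhibitor, a lower number a stronger inhibitor), compound 3 and compound 1 lie within the scatter of each other, while compound 2 stands clearly apart. In compound 4 `COC(=O)C1=CO[C@@H](O[C@@H]2O[C@H](COC(=O)c3cccc([N+](=O)[O-])c3)[C@@H](OC(C)=O)[C@H](OC(C)=O)[C@H]2OC(C)=O)[C@@H]2[C@@H](C)[C@@H](OC(C)=O)C[C@H]12`, 3-nitrophenyl replaces undecyl on a carbonyl carbon (3-nitrophenyl in place of undecyl on a carbonyl carbon). Among the measured compounds shown here, the only measured step at this carbonyl is modest but beyond the scatter: a 5.7-fold lower number from compound 2 to compound 3 (0.75 log units; beyond the scatter). It came with a longer chain, and compound 4 loses that chain, so part of the step may be reversed. For the measured compounds named here, no measured compound carries the new group, so this remains uncertain. The estimated step in this assay is a 2.7-fold higher number from compound 3 to compound 4 (0.43 log units; beyond the scatter). For compound 4 the expected value is 2 ug/mL, with an estimated range of 0.6 ug/mL to 6 ug/mL.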

Compound 4, half-maximal inhibitory concentration: 3.42 ug/mL
For compound 4 the middle estimate is 1.7-fold (0.23 log units) below the measured one; measured number inside the range.
By their numbers in this assay, from the lowest: compounds 3 and 1 (each within the scatter of the next); then compounds 4 and 2 (each within the scatter of the next).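

In this assay 3-nitrophenyl in place of undecyl on this carbonyl carbon gives a 4.6-fold higher number from compound 3 to compound 4 (0.66 log units; beyond the scatter) and so does not keep the low number seen with the long chain. Against the short ethyl group, the same change gives a 1.2-fold lower number from compound 2 to compound 4 (0.10 log units; within the scatter) and lies within the scatter. An aromatic ring at this carbonyl therefore reads no differently from ethyl, and only undecyl stands apart among these three. The compounds shown leave open how a plain phenyl or a mid-length chain such as hexyl would read at this carbonyl carbon. Nothing available explains either step.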